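The source may report more compounds than this note shows. Statements on the series, on what has been measured and on what is new or still open speak of the compounds shown alone.

In a functional assay on MCF7 cells (Homo sapiens) for cytotoxicity, read by MTT assay, with a stated time of 96 h (on this read-out lower numbers stand for stronger inhibition and higher numbers for weaker inhibition), compound 1 `COc1cc(C(=O)c2cn(-c3ccc(C)cc3)cc2-c2cccc([N+](=O)[O-])c2)cc(OC)c1OC` gives 210 nM, compound 2 `COc1cc(C(=O)c2cn(-c3ccc(C)cc3)cc2-c2ccc([N+](=O)[O-])cc2)cc(OC)c1OC` gives 200 nM, and compound 3 `COc1cc(C(=O)c2cn(-c3ccc(C)cc3)cc2-c2ccc(N)cc2)cc(OC)c1OC` gives 6 nM, the lowest of the three. The change a 1.1-fold lower number from compound 1 to compound 2 (0.02 log units; within the scatter) stays within the scatter, whereas amino in place of nitro gives a large step, a 33-fold lower number from compound 2 to compound 3 (1.52 log units; beyond the scatter). Compound 4 `COc1cc(C(=O)c2cn(-c3ccc(F)cc3)cc2-c2ccc(N)cc2)cc(OC)c1OC` keeps the 4-aminophenyl group of compound 3 but has fluoro in place of methyl on an aromatic carbon, turning 4-methylphenyl into 4-fluorophenyl. For the measured compounds named here, no measured step touches this place, so the data offer no direct guide, and no step beyond the scatter is expected in this assay. The expected change is small, a 1.5-fold higher number from compound 3 to compound 4 (0.18 log units; within the scatter). Compound 4 is estimated at 9 nM, with an expected range of 3 nM to 30 nM.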

Compound 4, half-maximal inhibitory concentration: 12 nM
For compound 4 the middle estimate is 1.3-fold (0.12 log units) below the measured one; low and high end bracket the measured number.
By their numbers in this assay, from the lowest: compounds 3 and 4 (each within the scatter of the next); then compounds 2 and 1 (each within the scatter of the next).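

In this assay, fluoro in place of methyl on the aromatic carbon para to a large group gives a 2.0-fold higher number from compound 3 to compound 4 (0.30 log units; within the scatter) with the 4-aminophenyl group kept. For the compounds shown here, this is the first look at this position, and here the change from 4-methylphenyl to 4-fluorophenyl leaves the number within the usual scatter. Nothing at hand explains why the two groups read alike. The compounds shown leave open how a larger group here, such as methoxy, trifluoromethyl or a longer chain like butyl, would read. On these data alone, an amine or a carboxylic acid at this position is equally open.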